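Chloro in Place of Methyl: From Compound 1 to Compound 3

The compounds below may be only part of what the source reports. "The series", "measured", "known", "first", "only" and "open" are said of these compounds alone.

Compound 1 `CC1=CC[C@H](C(C)C)c2cc(C)c(OC(=O)c3cccc(C)c3)cc21` was examined in a functional assay on HCT-15 cells (Homo sapiens) for antiproliferative activity, read by sulforhodamine B assay, with a stated time of 48 h, tested at 50 uM (a higher number here means more inhibition at the concentration tested (going by the name of the read-out), a lower number less inhibition), where compound 1 gives 5.3%. Within the data shown here, that is the lower of the two numbers measured so far. Among the measured compounds shown here, the only other measured compound, compound 2 `Cc1cc2c(C(C)C)ccc(C)c2cc1OC(=O)c1ccc(C(F)(F)F)cc1`, has a different core and differs from compound 1 in several places. In this assay compound 2 gives 55.6%, a number that lies beyond the scatter above compound 1. Those two compounds differ in several places at once. Their values show only that they stand far apart; no single change can be read from them.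

Compound 3 `CC1=CC[C@H](C(C)C)c2cc(C)c(OC(=O)c3cccc(Cl)c3)cc21` has not yet been measured. It arises from compound 1 through one change: chloro in place of methyl on an aromatic carbon. A methyl leaves and a chloro enters, each a single heavy atom, on an aromatic carbon of a six-membered aromatic ring of carbon only, meta to a large group. For the measured compounds named here, no measured pair in this set shows what such an exchange does in this assay, so the expectation rests on compound 1 alone. A small step upward, or none beyond the scatter, is expected: a number 9.7 percentage points higher from compound 1 to compound 3 (within the scatter). Compound 3 is accordingly estimated at 15%, with a range from 0% to 45%.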

Compound 3, a percentage reported as inhibition, at one concentration (the size of the read-out at that concentration, not a potency): 5.3%
For compound 3 the middle estimate is 9.7 percentage points above the measured one; low and high end bracket the measured number.
By their numbers in this assay, from the lowest: compounds 1 and 3 (each within the scatter of the next); then compound 2.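

Chloro in place of methyl on an aromatic carbon, meta to a large group, brings no change at the digits printed from compound 1 to compound 3 (within the scatter) in this assay, and this is the first single exchange in the set that can be read on its own. On the core of compound 1, then, 3-methylphenyl to 3-chlorophenyl is an exchange that this read-out, at its one tested concentration, does not separate, so the shared low reading of the pair is not tied to the methyl alone. Nothing at hand explains this result or bears on it.

As far as these compounds go, whether another group at this place, such as a methoxy, an amine or a carboxylic acid, would lift the number away from that of compound 1 remains open, and a single exchange at a single place cannot answer it. Also open, from the compounds shown here alone, are whether chloro would read the same elsewhere on that ring and whether the same exchange on a different core would again leave the number where it stands.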